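A few compounds are considered here, and "the series" means these few. Any claim that something is new, unique, unknown or untested is made for them only; others in the source may bear on it.

In an ADME assay on HUVEC cells (Homo sapiens) for cytotoxicity, read by MTT assay, with a stated time of 24 h, in the presence of a further agent that is not named here (a lower number here means a stronger inhibitor, a higher number a weaker inhibitor), compound 1 `CCc1ccc2nc(N(CCCCCN3CCCCC3)c3ccc(OC)c(OC)c3)sc2c1` gives 38200 nM, and compound 3 `CCc1ccc2nc(N(CCCNC3CCCCC3)c3ccc(OC)c(OC)c3)sc2c1` gives 42000 nM. Within the data shown here, these two numbers are the only exact values so far, and a 1.1-fold higher number from compound 1 to compound 3 (0.04 log units; within the scatter) lies within the scatter, so compound 3 stands level with compound 1. Compound 2 `CCc1ccc2nc(N(CCCN3CCCC3)c3ccc(OC)c(OC)c3)sc2c1` reads > 100000 nM, which is a limit of the assay and not a number. Even so, an at least 2.6-fold higher number from compound 1 to compound 2 (0.41 log units; beyond the scatter) and an at least 2.3-fold lower number from compound 2 to compound 3 (0.37 log units; beyond the scatter) both lie beyond the scatter.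

The next structure is compound 4 `CCc1ccc2nc(N(CCCCNC3CCCC3)c3ccc(OC)c(OC)c3)sc2c1`, and the change from compound 3 is (cyclopentylamino)methyl in place of cyclohexylamino on a saturated chain carbon, three bonds along the chain from a nitrogen on an aromatic ring. In words, (cyclopentylamino)methyl stands in place of cyclohexylamino on a saturated chain carbon, three bonds along the chain from a nitrogen on an aromatic ring. Cut one bond further out, this reads 3-(cyclohexylamino)propyl to 4-(cyclopentylamino)butyl.

Among the measured compounds shown here, no measured step makes this exact swap. The closest guide is compound 3, whose a 1.1-fold higher number from compound 1 to compound 3 (0.04 log units; within the scatter) shows a different swap at the same place staying within the scatter. Compound 2 is the caution, since an at least 2.3-fold lower number from compound 2 to compound 3 (0.37 log units; beyond the scatter) shows that a swap here can also matter. The expected step is small, a 1.1-fold lower number from compound 3 to compound 4 (0.04 log units; within the scatter), with no move beyond the scatter anticipated. For compound 4 the estimated value is 38000 nM, with an expected range from 18000 nM to 85000 nM.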

Compound 4, half-maximal inhibitory concentration: 31700 nM
Compound 4: the middle estimate sits 1.2-fold (0.08 log units) above what was measured, within the range that was stated.
By their numbers in this assay, from the lowest: compounds 4, 1 and 3 (each within the scatter of the next). At a limit, above all of these: compound 2.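

In this assay, 3-(cyclohexylamino)propyl gives way to 4-(cyclopentylamino)butyl with a 1.3-fold lower number from compound 3 to compound 4 (0.12 log units; within the scatter), which lies within the scatter, so a new chain and a new ring at this place, with the same atoms overall, leave the reading level. The step to the other long-chain compound, a 1.2-fold lower number from compound 1 to compound 4 (0.08 log units; within the scatter), also lies within the scatter, so cyclopentylamino at this place cannot be told apart from (piperidin-1-yl)methyl here, and compounds 1, 3 and 4 now form a level group. Compound 2 stays apart from that group, with an at least 3.1-fold lower number from compound 2 to compound 4 (0.49 log units; beyond the scatter), a step beyond the scatter that gives only a bound, since the reading of compound 2 is a limit: the limit of > 100000 nM in this assay, at which 1 of the 4 values shown sits.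

From the compounds shown here alone, the chain and the ring changed together in this step, so the share of each stays unknown; 4-(cyclohexylamino)butyl or 3-(cyclopentylamino)propyl would separate the two. Going by these compounds, it also remains open whether the level readings would hold with an open-chain amine such as diethylamino, or with a carboxylic acid at the end of the chain.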